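Moving the methoxy group on the aryl of compound 3

The compounds below may be only part of what the source reports. "The series", "measured", "known", "first", "only" and "open" are said of these compounds alone.

The three measured compounds share one core and differ at two aryl groups. Compound 1 `COc1cccc(-c2c(S(=O)(=O)c3cc(Cl)cc(Cl)c3)cnc3c(F)cccc23)c1` gives 2.31 mL/min in an ADME assay on microsomes from liver (Homo sapiens) for metabolic stability, tested at 2.5 uM; on this read-out higher numbers stand for fast clearance and lower numbers for slow clearance. Going by the values given here, compound 2 `COc1ccc(S(=O)(=O)c2cnc3c(F)cccc3c2-c2cccc(OC)c2)cc1` gives 2.87 mL/min in this assay, and the only single-point step among the measured compounds is a 1.2-fold higher number from compound 1 to compound 2 (0.09 log units; within the scatter). Compound 3 `COc1ccc(-c2c(S(=O)(=O)c3cccc(F)c3)cnc3c(F)cccc23)cc1` gives 2.48 mL/min in this assay, which places it second highest of the three numbers; its gap to compound 1 and its gap to compound 2 both lie within the scatter, so the three compounds cannot be ordered on these data.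

Compound 4 `COc1cccc(-c2c(S(=O)(=O)c3cccc(F)c3)cnc3c(F)cccc23)c1` has not yet been measured. It differs from compound 3 in one place: 3-methoxyphenyl in place of 4-methoxyphenyl on an aromatic carbon. Among the compounds with values here, no measured step changes this group, so nothing bears on it directly; what the data do show is that compounds 1 and 2, which carry 3-methoxyphenyl, and compound 3, which carries 4-methoxyphenyl, all sit within the scatter of one another. The step is therefore expected to be none beyond the scatter, a 1.0-fold higher number from compound 3 to compound 4 (0.00 log units; within the scatter). Compound 4 is estimated at 2.5 mL/min, within a range of 1.5 mL/min to 4.2 mL/min.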

Compound 4, intrinsic clearance in a liver preparation (reported as CLH), per the amount of preparation that the assay uses: 2.6 mL/min
Estimate against measurement, compound 4: 1.0-fold (0.02 log units) below; measured number inside the range.
By their numbers in this assay, from the lowest: compounds 1, 3, 4 and 2 (each within the scatter of the next).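

In this assay, going by these compounds alone, 3-methoxyphenyl in place of 4-methoxyphenyl on the aromatic carbon opposite the ring nitrogen gives a 1.0-fold higher number from compound 3 to compound 4 (0.02 log units; within the scatter), the first measured step at this place, so the two methoxy arrangements are not told apart here. With 3-methoxyphenyl held fixed, the group on the sulfonyl sulfur can also be read: 3-fluorophenyl in place of 4-methoxyphenyl gives a 1.1-fold lower number from compound 2 to compound 4 (0.04 log units; within the scatter) and 3-fluorophenyl in place of 3,5-dichlorophenyl gives a 1.1-fold higher number from compound 1 to compound 4 (0.05 log units; within the scatter). Neither place separates these compounds on this read-out.

Nothing shown offers an explanation for how closely these numbers agree. As far as these compounds go, whether an amine or a carboxylic acid on either aryl group would give a step beyond the scatter remains open.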